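The compounds below may be only part of what the source reports. "The series", "measured", "known", "first", "only" and "open" are said of these compounds alone.

Measured compounds:
compound 1, `CC(C)[C@H](NC(=O)c1ccccc1)C(=O)N1CCC[C@H]1C(=O)N[C@@H](CCCNC(=N)N)C(=O)CF`: 660 nM
compound 2, `CC(C)[C@H](NC(=O)c1ccc(Br)cc1)C(=O)N1CCC[C@H]1C(=O)N[C@@H](CCCNC(=N)N)C(=O)CF`: 130 nM
compound 3, `CC(C)[C@H](NC(=O)c1ccc(C(F)(F)F)cc1)C(=O)N1CCC[C@H]1C(=O)N[C@@H](CCCNC(=N)N)C(=O)CF`: 120 nM

In a functional assay on OCI-Ly3 cells (Homo sapiens) for inhibition, read by CellTiter-Glo, with stated times of 48 h and 96 h (on this read-out lower numbers stand for stronger inhibition of growth and higher numbers for weaker inhibition of growth), compound 1 stands highest of the three numbers, so among these it shows the weakest inhibition. Compound 2 and compound 3 both carry a group on the aromatic ring that compound 1 lacks, and both give clearly lower numbers: a 5.1-fold lower number from compound 1 to compound 2 (0.71 log units; beyond the scatter) and a 5.5-fold lower number from compound 1 to compound 3 (0.74 log units; beyond the scatter). Between those two the difference is small, a 1.1-fold lower number from compound 2 to compound 3 (0.03 log units; within the scatter), so which group sits on the ring made little difference here.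

Compound 4, `CC(C)[C@H](NC(=O)Nc1ccc(Cl)cc1)C(=O)N1CCC[C@H]1C(=O)N[C@@H](CCCNC(=N)N)C(=O)CF`, is not yet measured. It differs from compound 1 in one place: (4-chlorophenyl)amino in place of phenyl on a carbonyl carbon. This change has two parts. A chlorine on the ring, in the same position as the bromo of compound 2 and the trifluoromethyl of compound 3, resembles the changes that gave the two measured steps. The added nitrogen between the carbonyl and the ring has no measured counterpart among these compounds, so its effect is unknown. On the strength of the two measured steps, a lower number is expected for compound 4, though with a wide range, and the expected step is a 3.3-fold lower number from compound 1 to compound 4 (0.52 log units; beyond the scatter). The estimate for compound 4 is 200 nM, between 60 nM and 700 nM.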

Compound 4, concentration for 50% growth inhibition: 780 nM
The estimate for compound 4 lay 3.9-fold (0.59 log units) below the measured number, outside the stated range (above it).
By their numbers in this assay, from the lowest: compounds 3 and 2 (each within the scatter of the next); then compounds 1 and 4 (each within the scatter of the next).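

Placing (4-chlorophenyl)amino on the carbonyl carbon leaves compound 4 within the scatter of compound 1 in this assay (a 1.2-fold higher number from compound 1 to compound 4 (0.07 log units; within the scatter)), so a ring substituent in this series does not bring a lower number under every circumstance. The lower numbers of compound 2 and compound 3 therefore do not extend to this change, as the listed steps show (a 6.0-fold higher number from compound 2 to compound 4 (0.78 log units; beyond the scatter); a 6.5-fold higher number from compound 3 to compound 4 (0.81 log units; beyond the scatter)), and this position responds to more than the presence of a group on the ring. No measurement at hand bears on the reason for this result.

Chlorine and the added nitrogen arrive together in compound 4, so their separate contributions remain unknown, and it is also open whether chlorine on the ring would match bromo and trifluoromethyl. A 4-chlorophenyl group attached straight to the carbonyl carbon, and an unsubstituted phenylamino group in the same place, would each isolate one part of the change.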